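The source may hold more compounds than are shown below. What is called first, only, known or untested is meant among the compounds shown, and "the series" means these compounds.

Measured so far:
- compound 1, `[N-]=[N+]=NCc1cn([C@H]2C[C@H](O)[C@@H](CO)O2)c(=O)[nH]c1=O`, gives 124000 nM.
- compound 2, `OC[C@@H]1[C@@H]2COC[C@H]2C[C@H]1n1cnc2c(Cl)ncnc21`, is reported only as a limit of the assay, > 200000 nM.
- compound 3, `CCC#Cc1cn([C@@H]2O[C@H](CO)[C@@H](O)[C@@H]2O)c(=O)[nH]c1=O`, is also reported only as a limit, > 200000 nM.

These three values come from an ADME assay on L1210/0 cells (Mus musculus) for cytotoxicity, with a stated time of 48 h; on this read-out higher numbers stand for weaker inhibition and lower numbers for stronger inhibition. Among the compounds with values here, compound 1 stands as the only compound with a real number in this assay; the other two results are limits, described by the limit of > 200000 nM in this assay, at which 2 of the 3 values shown sit. Within the data shown here, with no two compounds differing in a single place, no measured step can be drawn, and compound 1 is the sole anchor for what follows.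

Compound 4, `O=c1[nH]c(=O)n([C@H]2C[C@H](O)[C@@H](CO)O2)cc1O`, is not yet measured. It differs from compound 1 in one place: hydroxy in place of azidomethyl on an aromatic carbon. Both share the same core, and the change touches only the group on that aromatic carbon.

Among the measured compounds shown here, no measured pair shows how this kind of swap moves the read-out, so the expected step in this assay rests on compound 1 alone. The step from compound 1 to compound 4 is expected to be small, with no clear direction beyond the scatter, so that a 1.2-fold higher number from compound 1 to compound 4 (0.08 log units; within the scatter) is estimated to stay near zero. Compound 4 is therefore expected to give about 150000 nM, within a range from 50000 nM to 400000 nM, with a fair chance that only a limit is reported.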

Compound 4, half-maximal inhibitory concentration: > 200000 nM
Compound 4: no number, only a limit; the forecaster's own chance of this, stated with the estimate: 35%; middle value at least 1.3-fold (0.12 log units) away from the limit.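

In this assay, within the data shown here, putting hydroxy in place of azidomethyl on this aromatic carbon gives the only step that can be read so far: an at least 1.6-fold higher number from compound 1 to compound 4 (0.20 log units; that floor lies within the scatter). That figure is a floor rather than a measured size, and it lies within the scatter, so the result shows that this swap brought no sign of stronger inhibition at this position but cannot say how far the read-out moved. Among these compounds, compound 4 is reported only as a limit, so compound 1 remains the only compound with a real number, and its modest value is the sole trace of activity against these cells, while the rest sit at the ceiling of the assay: the limit of > 200000 nM in this assay, at which 3 of the 4 values shown sit.

The compounds shown leave open whether the azidomethyl group itself accounts for the real number of compound 1, or whether almost any group on this carbon would give a similar result. An aminomethyl group, which keeps the carbon and replaces the azide with an amine, or a longer chain at the same place, would help to separate these two readings, provided the result falls inside the measurable range.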